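Pyrazolone amides with a thienopyrimidine ether: note on compound 3

The source may hold more compounds than are shown below. What is called first, only, known or untested is meant among the compounds shown, and "the series" means these compounds.

Measured so far:
compound 1, `Cc1cc(=O)n(-c2cccc(F)c2)nc1C(=O)Nc1ccc(Oc2ncnc3ccsc23)cc1`, 9540 nM
compound 2, `Cc1cc(=O)n(-c2ccc(Br)cc2F)nc1C(=O)Nc1ccc(Oc2ncnc3sccc23)cc1`, 12800 nM

Both compounds were run in a functional assay on A549 cells (Homo sapiens) for cytotoxicity, read by MTT assay, with a stated time of 72 h; on this read-out lower numbers stand for stronger inhibition and higher numbers for weaker inhibition. In this assay compound 1 gives 9540 nM, and compound 2 gives 12800 nM. Compound 2 carries the highest of the two numbers, but its nearest neighbour is compound 1 and the gap between them lies within the scatter, so no order between the two can be read from these values. For the measured compounds named here, no step between measured compounds that differ in one place is available in this set.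

Compound 3, `Cc1cc(=O)n(-c2cccc(F)c2)nc1C(=O)Nc1ccc(Oc2ncnc3sccc23)cc1`, has not yet been measured in this assay. Relative to compound 2 the change is 3-fluorophenyl in place of 4-bromo-2-fluorophenyl on an aromatic nitrogen, in words 3-fluorophenyl in place of 4-bromo-2-fluorophenyl on an aromatic nitrogen. Compound 3 thus pairs the aryl group of compound 1 with the core of compound 2. Since compound 1 at 9540 nM and compound 2 at 12800 nM sit within the scatter of each other, no step beyond the scatter is expected from compound 2 to compound 3, a 1.3-fold lower number from compound 2 to compound 3 (0.11 log units; within the scatter). Compound 3 is estimated at 10000 nM, with a range of 4000 nM to 25000 nM.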

Compound 3, half-maximal inhibitory concentration: 16400 nM
Compound 3: the middle estimate sits 1.6-fold (0.21 log units) below what was measured; measured number inside the range.
By their numbers in this assay, from the lowest: compounds 1, 2 and 3 (each within the scatter of the next).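

On the aromatic nitrogen, 3-fluorophenyl in place of 4-bromo-2-fluorophenyl gives in this assay a 1.3-fold higher number from compound 2 to compound 3 (0.11 log units; within the scatter), so this first one-place change at the position, which also removes the bromine, leaves the number within the scatter. On the oxygen on an aromatic ring, exchanging one group for another of the same heavy-atom composition gives a 1.7-fold higher number from compound 1 to compound 3 (0.24 log units; within the scatter), so neither single change shown moves the number beyond the scatter. Nothing available here offers an explanation for the size of these steps.

From the compounds shown here alone, whether any replacement on this nitrogen can move the number beyond the scatter stays open, for example a carboxylic acid or an amine on the phenyl ring, or a plain methyl group or longer alkyl chain in place of the aryl ring. Also open, going by these compounds, is the contribution of the methyl group on the shared core and of the amide hydrogen, since all three compounds carry both unchanged, and whether these small steps would hold in cell lines other than the one used here.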